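The source may report more compounds than this note shows. Statements on the series, on what has been measured and on what is new or still open speak of the compounds shown alone.

Measured so far in a functional assay on A549 cells (Homo sapiens) for antiproliferative activity, read by sulforhodamine B assay, with a stated time of 72 h; a higher number here means a weaker inhibitor, a lower number a stronger inhibitor:

- Compound 1 `CC(=O)Nc1ccc(S(=O)(=O)Nc2cc(SCC(=O)N[C@@H](CC(C)C)B(O)O)c(O)c3ccccc23)cc1`: 6700 nM
- Compound 2 `CC(C)C[C@H](NC(=O)CCSc1cc(NS(=O)(=O)c2cccs2)c2ccccc2c1O)B(O)O`: 5930 nM

The two compounds cannot be told apart on these numbers. In this assay compound 2 gives 5930 nM, and this lies within the usual scatter of repeated measurements of compound 1 at 6700 nM. Neither can be ranked over the other.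

The next compound is compound 3 `CC(=O)Nc1ccc(S(=O)(=O)Nc2cc(SCCC(=O)N[C@@H](CC(C)C)B(O)O)c(O)c3ccccc23)cc1`. It has 4-acetamidophenyl in place of thiophen-2-yl on a sulfonyl sulfur when set against compound 2: 4-acetamidophenyl in place of thiophen-2-yl on a sulfonyl sulfur. The swap brings in a larger group, but size alone does not predict the result. Within the data shown here, no measured pair shows this change on its own, so there is no direct precedent for it. Among the measured compounds shown here, the only indirect guide is compound 1, which also carries 4-acetamidophenyl and gives 6700 nM. On that basis, no change beyond the scatter is expected in this assay, in either direction.

The estimated change is a 1.1-fold lower number from compound 2 to compound 3 (0.03 log units; within the scatter). The estimate for compound 3 is 5500 nM, with an expected range from 2200 nM to 13000 nM.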

Compound 3, half-maximal inhibitory concentration: 5920 nM
Compound 3: middle estimate off by 1.1-fold (0.03 log units), on the low side; the measured number falls inside the stated range.
By their numbers in this assay, from the lowest: compounds 3, 2 and 1 (each within the scatter of the next).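

The swap of thiophen-2-yl for 4-acetamidophenyl on a sulfonyl sulfur now has a direct reading: in this assay, going from 5 to 10 heavy atoms at this place, with one hydrogen-bond donor gained, gives a 1.0-fold lower number from compound 2 to compound 3 (0.00 log units; within the scatter). Among these compounds, the new compound also gives a first one-place comparison in the chain on the other side of the core, where a group of 12 heavy atoms in place of a group of 11 heavy atoms, on a saturated chain carbon bound to a sulfur, gives a 1.1-fold lower number from compound 1 to compound 3 (0.05 log units; within the scatter). Nothing at hand explains why neither step goes beyond the scatter.

From the compounds shown here alone, with only thiophen-2-yl and 4-acetamidophenyl on the sulfonyl sulfur, it remains open whether a small methyl group there, or a phenyl ring carrying a carboxylic acid or an amine, would separate from these values. Going by these compounds, it also remains open whether a longer chain on the sulfur than the two compared here would give a number beyond the scatter.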